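From Compound 2 to Compound 3: a Cytotoxicity Estimate

The source may report more compounds than this note shows. Statements on the series, on what has been measured and on what is new or still open speak of the compounds shown alone.

Of the compounds shown here, two have been measured so far. Compound 1 `COc1ccc(/C=C/S(=O)(=O)Nc2ccc(OC)c(F)c2)cc1` in a functional assay on K562 cells (Homo sapiens) for cytotoxicity, read by trypan blue exclusion, with a stated time of 96 h (a lower number here means a stronger inhibitor, a higher number a weaker inhibitor), gives 1000 nM. Compound 2 `COC(=O)C(C)Nc1cc(NS(=O)(=O)/C=C/c2c(OC)cc(OC)cc2OC)ccc1OC` in this assay gives 300 nM, the lowest of the two numbers and separated from compound 1 by a gap beyond the usual scatter, so compound 2 is the stronger of the pair.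

Compound 3 `COc1cc(OC)c(/C=C/S(=O)(=O)Nc2ccc(OC)c(NC(C(=O)O)c3ccc(Br)cc3)c2)c(OC)c1` is not yet measured. It differs from compound 2 in one place: (4-bromophenyl)(carboxy)methyl in place of 1-(methoxycarbonyl)ethyl on a nitrogen on an aromatic ring. The group that enters is larger, brings a six-membered aromatic ring with bromine, and carries a carboxy group in place of the methoxycarbonyl one. For the measured compounds named here, no measured pair shows this kind of change, so its effect is unknown here.

The expectation is a modest step, from compound 2 to compound 3 of a 1.3-fold higher number from compound 2 to compound 3 (0.12 log units; within the scatter), with no strong reason to lean to either side. Compound 3 is therefore estimated at 400 nM in this assay, within the range 100 nM to 1600 nM.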

Compound 3, half-maximal inhibitory concentration: 75 nM
The estimate for compound 3 lay 5.3-fold (0.73 log units) above the measured number, outside the stated range (below it).
By their numbers in this assay, from the lowest: compound 3; then compound 2; then compound 1.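

In this assay, the position on a nitrogen on an aromatic ring accepts a larger group: (4-bromophenyl)(carboxy)methyl in place of 1-(methoxycarbonyl)ethyl gives a 4.0-fold lower number from compound 2 to compound 3 (0.60 log units; beyond the scatter). This is the first measured change in a single place among these compounds, and it shows that this position influences the read-out and that the change as a whole strengthens inhibition here. Nothing measured here explains the stronger result.

The change swaps the ester for a carboxy group and adds the bromine-bearing aromatic ring at once, and the compounds shown cannot say which part carries the step. A 1-carboxyethyl group or a (4-bromophenyl)(methoxycarbonyl)methyl group on the same nitrogen would separate the two parts, and a plain phenyl ring in place of the 4-bromophenyl would isolate the bromine.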